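Chloro for Fluoro on the Anilide of a Benzamide Series

The source may hold more compounds than are shown below. What is called first, only, known or untested is meant among the compounds shown, and "the series" means these compounds.

Measured compounds:
Compound 1, `N#Cc1cc(F)cc(C(=O)Nc2ccccn2)c1`: 3010 nM
Compound 2, `N#Cc1cc(F)cc(C(=O)Nc2cccc(F)c2)c1`: 2160 nM
Compound 3, `N#Cc1cc(F)cc(C(=O)Nc2ccc(F)cc2)c1`: > 10000 nM

Three amides built on a shared core have been tested in an in vitro functional assay on HEK293-A cells for antagonist activity at metabotropic glutamate receptor 5 (Rattus norvegicus), read by calcium flux; a higher number here means a weaker inhibitor, a lower number a stronger inhibitor. Compound 2 gives 2160 nM, the lowest of the two numbers reported. Compound 1 gives 3010 nM, which lies within the scatter of compound 2, so the two cannot be ranked. For compound 3 the assay reports only a limit, > 10000 nM, and no number (the limit of > 10000 nM in this assay, at which 1 of the 3 values shown sits).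

Compound 4, `N#Cc1cc(F)cc(C(=O)Nc2cccc(Cl)c2)c1`, has not yet been measured in this assay. It differs from compound 2 by chloro in place of fluoro on an aromatic carbon, on a six-membered aromatic ring of carbon only, meta to a large group. Among the measured compounds shown here, no measured pair shows this change, so its size is an open question; a modest shift in either direction, or none beyond the scatter, seems the most likely outcome.

Compound 4 is therefore expected to give 1500 nM, within a range of 400 nM to 6000 nM, which means an estimated step of a 1.4-fold lower number from compound 2 to compound 4 (0.16 log units; within the scatter).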

Compound 4, half-maximal inhibitory concentration: 45 nM
Compound 4: middle estimate off by 33-fold (1.52 log units), on the high side; measured number below the stated range.
By their numbers in this assay, from the lowest: compound 4; then compounds 2 and 1 (each within the scatter of the next). At a limit, above all of these: compound 3.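

Exchanging one halogen for another, with one heavy atom leaving, one entering, and no change in ring count, hydrogen-bond donors or acceptors, or charge, gives a 48-fold lower number from compound 2 to compound 4 (1.68 log units; beyond the scatter). Among the compounds shown here, this is the first measured pair with a single change, and it shows that this aromatic carbon, meta to a large group, is far from indifferent to the group it carries: a small exchange here can separate a weak inhibitor from a much stronger one. Nothing measured here accounts for the size of this step.

Going by these compounds, whether a bromo, methyl or methoxy group on the same carbon would give a still lower number remains open. So does whether the gain from chloro would carry over to other amides on the shared core, such as compound 1 or compound 3.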